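Thiazolidine amides with a long chain: aryl swaps at the ring carbon

The source may report more compounds than this note shows. Statements on the series, on what has been measured and on what is new or still open speak of the compounds shown alone.

Measured in a functional assay on RH7777 cells (Homo sapiens) for antiproliferative activity against RH7777 (Rattus norvegicus), read by sulforhodamine B assay; on this read-out higher numbers stand for weaker inhibition and lower numbers for stronger inhibition:
- Compound 1, `CCCCCCCCCCCCCCCCCCNC(=O)[C@H]1CSC(Cc2ccccc2)N1`, sits at the assay limit, > 20000 nM.
- Compound 2, `CCCCCCCCCCCCCCCCCCNC(=O)[C@H]1CSC(c2c[nH]c3ccccc23)N1`, sits at the assay limit, > 20000 nM.
- Compound 3, `CCCCCCCCCCCCCCCCCCNC(=O)[C@H]1CSC(c2ccc(Br)cc2)N1`, sits at the assay limit, > 20000 nM.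

Compound 3 stands at a limit only, as do the other two; (the limit of > 20000 nM in this assay, at which 3 of the 3 values shown sit). The steps a step that the two limits leave unreadable from compound 1 to compound 2, a step that the two limits leave unreadable from compound 1 to compound 3 and a step that the two limits leave unreadable from compound 2 to compound 3 are all unreadable for that reason, so no aryl swap at this carbon has yet produced a number.

Compound 4, `CCCCCCCCCCCCCCCCCCNC(=O)[C@H]1CSC(c2cc(F)cc(F)c2)N1`, differs from compound 3 thus: 3,5-difluorophenyl in place of 4-bromophenyl on a saturated ring carbon.

Among the compounds with values here, no measured step bears readably on this change. Compound 4 is expected to remain at the limit, estimated 30000 nM (range 12000 nM to 80000 nM), which would mean an expected step that the limit leaves unreadable from compound 3 to compound 4.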

Compound 4, half-maximal inhibitory concentration: > 20000 nM
Compound 4 was reported as a limit (the forecaster's own chance of this, stated with the estimate: 80%); the middle value is on the limit's open side.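

Compound 4 gives only a limit, as do compound 1, compound 2 and compound 3, so no step among these four can be read: the limit of > 20000 nM in this assay, at which 4 of the 4 values shown sit. The compounds shown leave open whether any group at this ring carbon gives a measurable value.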